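Swapping an Ethoxy for a Methoxymethyl on the Shared Core

The compounds below may be only part of what the source reports. "The series", "measured", "known", "first", "only" and "open" are said of these compounds alone.

Of the compounds shown here, two have been measured in an ADME assay on MT2 cells (Homo sapiens) for inhibition; on this read-out lower numbers stand for higher toxicity in this test and higher numbers for lower toxicity in this test. Compound 1 `N#Cc1ccc(Nc2ncc(Cc3c(F)cc(F)cc3F)o2)cc1Cl` gives 7000 nM. For the measured compounds named here, compound 2 `CCOc1cc(F)c(Cc2cnc(Nc3ccc(C#N)c(Cl)c3)o2)c(F)c1` gives 15000 nM, the highest of the two numbers, and the only step between them, a 2.1-fold higher number from compound 1 to compound 2 (0.33 log units; beyond the scatter), lies beyond the scatter. Compound 3 `COCc1cc(F)c(Cc2cnc(Nc3ccc(C#N)c(Cl)c3)o2)c(F)c1` differs from compound 2 by methoxymethyl in place of ethoxy on an aromatic carbon; the two have the same atoms, joined differently. Going by the values given here, no measured step concerns the exchange of one such three-atom group for another at this position: the single step known, from fluoro to ethoxy, is of a different kind and so gives no direct guide. With only that to go on, the number for compound 3 is expected to stay close to that of compound 2, a step of no change at the digits printed from compound 2 to compound 3 (within the scatter), which is none beyond the scatter. Compound 3 is therefore estimated at 15000 nM, within 7000 nM to 32000 nM.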

Compound 3, half-maximal cytotoxic concentration: 15000 nM
For compound 3 middle estimate and measured number coincide at the digits printed; the measured number falls inside the stated range.
By their numbers in this assay, from the lowest: compound 1; then compounds 2 and 3 (each within the scatter of the next).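

In this assay, ethoxy and methoxymethyl hold the same atoms joined differently, yet the exchange gives no change at the digits printed from compound 2 to compound 3 (within the scatter), so at this position on the shared core that rearrangement leaves the reading unmoved. Set against the fluoro group, methoxymethyl gives a 2.1-fold higher number from compound 1 to compound 3 (0.33 log units; beyond the scatter), a modest step beyond the scatter, which shows that the rise seen with ethoxy is not confined to that one group. Nothing measured here explains why the two groups read alike.

Going by these compounds, it remains open whether a group of another kind at this position, such as an amine or a carboxylic acid, would move the number further. A longer chain, such as butoxy, could also show whether the number keeps rising with size or has already levelled off.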